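This account rests on a few compounds, and the source may have more. Where it says the series, first, only, none or still open, it means among the compounds named here.

Measured compounds:
compound 1 `CCCCCCCCCCc1ccc(-c2noc(C3CNC3)n2)cc1`, 65% in an assay on HeLa cells for inhibition of sphingosine-1-phosphate transporter SPNS2 (Mus musculus), read by LC-MS, tested at 2 uM; a lower number here means less inhibition, a higher number more inhibition at the concentration tested (going by the name of the read-out)
compound 2 `CCCCCCCCCCc1ccc(-c2noc(CCCNC)n2)cc1`, 45%
compound 3 `CCCCCCCCCCc1ccc(-c2noc(CCCN(C)C)n2)cc1`, 8%

Compound 2 stands second highest of the three, with compound 1 giving a number a number 20 percentage points lower from compound 1 to compound 2 (beyond the scatter) and compound 3 a number a number 37 percentage points lower from compound 2 to compound 3 (beyond the scatter). Compound 4 `CCCCCCCCCCc1ccc(-c2noc([C@H](CCCCN)NC(C)=O)n2)cc1` is not yet measured. Its change from compound 2 is 1-acetamido-5-aminopentyl in place of 3-(methylamino)propyl on an aromatic carbon. For the measured compounds named here, no measured step makes this exact change. The nearest guide is the step of a number 37 percentage points lower from compound 2 to compound 3 (beyond the scatter), where adding a methyl to the amine nitrogen lowered inhibition strongly; compound 4 instead keeps an amine carrying two hydrogens, while the chain grows and gains an acetamido group. The inhibition of compound 4 is therefore expected to stay near that of compound 2, with a step of a number 3 percentage points higher from compound 2 to compound 4 (within the scatter), and compound 4 is estimated at 48%, between 20% and 75%.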

Compound 4, a percentage reported as inhibition, at one concentration (the size of the read-out at that concentration, not a potency): 40%
Compound 4: middle estimate off by 8 percentage points, on the high side, within the range that was stated.
By their numbers in this assay, from the lowest: compound 3; then compounds 4 and 2 (each within the scatter of the next); then compound 1.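

The much larger 1-acetamido-5-aminopentyl group is accepted at this position on the shared core, and its size and added acetamido group leave the number level with that of 3-(methylamino)propyl (a number 5 percentage points lower from compound 2 to compound 4 (within the scatter)). The same group gives clearly more inhibition than 3-(dimethylamino)propyl (a number 32 percentage points higher from compound 3 to compound 4 (beyond the scatter)) but less than azetidin-3-yl (a number 25 percentage points lower from compound 1 to compound 4 (beyond the scatter)). No measurement here explains these steps. As far as these compounds go, whether the terminal amine of the new chain is needed remains open, as does the effect of a carboxylic acid in its place.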